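Chain extension in a series with no measurable binding

A few compounds are considered here, and "the series" means these few. Any claim that something is new, unique, unknown or untested is made for them only; others in the source may bear on it.

Compound 1 `CS(=O)(=O)c1ccc(C(=O)NCCC(=O)N2CCCCC2)cc1[N+](=O)[O-]` carries a nitro and methylsulfonyl group on the shared core. In an assay on isolated protein for inhibition of vitamin D3 receptor (Homo sapiens), read by fluorescence polarization (on this read-out higher numbers stand for weaker inhibition and lower numbers for stronger inhibition), compound 1 gives > 60000 nM, which is a limit of the assay and not a number. Compound 2 `CS(=O)(=O)c1ccc(C(=O)NCCC(=O)N2CCc3ccccc32)cc1[N+](=O)[O-]` gives > 60000 nM in this assay, again only a limit. Compound 3 `CS(=O)(=O)c1ccc(C(=O)NCCC(=O)N2CCc3ccccc3C2)cc1[N+](=O)[O-]` gives > 60000 nM, also a limit. The steps a step that the two limits leave unreadable from compound 1 to compound 2, a step that the two limits leave unreadable from compound 1 to compound 3 and a step that the two limits leave unreadable from compound 2 to compound 3 therefore stay unreadable, since every value sits at the limit of > 60000 nM in this assay, at which 3 of the 3 values shown sit. Compound 4 `CS(=O)(=O)c1ccc(C(=O)NCCCC(=O)N2CCCCC2)cc1[N+](=O)[O-]` differs from compound 1 by ((piperidin-1-yl)carbonyl)methyl in place of (piperidin-1-yl)carbonyl on a saturated chain carbon, two bonds along the chain from an amide-type nitrogen. Among the compounds with values here, no measured step bears on this one-carbon lengthening of the chain, and the three limits give no direction to build on. Compound 4 is estimated at 100000 nM, with a range from 30000 nM to 300000 nM. The step that the limit leaves unreadable from compound 1 to compound 4 is expected to remain unreadable, most likely as another limit.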

Compound 4, half-maximal inhibitory concentration: > 60000 nM
Compound 4 was reported as a limit; the forecaster's own chance of this, stated with the estimate: 85%; the middle value does not contradict the limit.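

Within the data shown here, compound 1 and compound 4 both stand only as limits of the assay, so no step between them can be read. The compounds shown leave open whether any change gives a measurable value in this assay at all.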